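The compounds below may be only part of what the source reports. "The series", "measured", "known", "first", "only" and "open" are said of these compounds alone.

Compound 1 `CSc1cccc(N2CCN(C3CN4CCC3CC4)C2=O)c1` gives 214 nM in a functional assay (Cavia porcellus) for antagonist activity at Serotonin 3 (5-HT3) receptor (Homo sapiens); on this read-out lower numbers stand for stronger inhibition and higher numbers for weaker inhibition. Compound 2 `Cc1[nH]cnc1CN1CCN(c2cccc(Cl)c2)C1=O` gives 12 nM. Compound 3 `Cc1[nH]cnc1CN1CCN(c2cc(Cl)cc(Cl)c2)C1=O` gives 5.62 nM.

Compound 2 stands second highest of these three numbers; compound 3 is nearest to it and compound 1 furthest from it. Compound 4 `Cc1cccc(N2CCN(Cc3nc[nH]c3C)C2=O)c1` differs from compound 2 by methyl in place of chloro on an aromatic carbon. Within the data shown here, only one measured step involves a chloro group: a 2.1-fold lower number from compound 2 to compound 3 (0.33 log units; beyond the scatter). Among the measured compounds shown here, no measured pair exchanges chloro for methyl, and compound 1 differs from the others in several places at once, so it gives no guidance. A small rise in the number, close to the scatter, is therefore expected: a 1.7-fold higher number from compound 2 to compound 4 (0.22 log units; within the scatter). Compound 4 is estimated at 20 nM, with a range from 6 nM to 65 nM.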

Compound 4, antagonist equilibrium constant: 45.7 nM
Estimate against measurement, compound 4: 2.3-fold (0.36 log units) below; the measured number falls inside the stated range.
By their numbers in this assay, from the lowest: compound 3; then compound 2; then compound 4; then compound 1.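

In this assay, replacing the chloro on the aromatic ring with a methyl gives a 3.8-fold higher number from compound 2 to compound 4 (0.58 log units; beyond the scatter) and this step lies beyond the scatter. This place on the ring is therefore sensitive to which group sits there, even though chloro and methyl each count as one heavy atom. No measurement offered here explains the step.

On these data alone, it remains open whether a methoxy or trifluoromethyl group at this place would give a number nearer that of compound 2 or compound 4. Also open, as far as these compounds go, is whether the same exchange would have a similar effect in compound 3.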